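The source may report more compounds than this note shows. Statements on the series, on what has been measured and on what is new or still open speak of the compounds shown alone.

Compound 2, `COc1ccc(-c2nc(C)c(C(=O)CSc3nc(-c4ccc(OC)c(OC)c4)c(C#N)c(=O)[nH]3)s2)cc1`, is the starting point. In an assay on membranes from CHO cells for displacement of a labelled ligand from adenosine receptor A1 (Homo sapiens), read by scintillation counting, with a stated time of 60 min, tested at 1 uM (on this read-out lower numbers stand for less inhibition and higher numbers for more inhibition at the one concentration tested (going by the name of the read-out)), compound 2 gives 2.5%, the highest of the three numbers recorded so far. Compound 1, `COc1ccc(-c2nc(SCC(=O)c3sc(-c4ccccc4)nc3C)nc(N)c2C#N)cc1`, is the nearest neighbour: in this assay compound 1 gives -4.6%, which lies within the usual scatter of compound 2. Compound 3, `Cc1nc(-c2ccccc2)sc1C(=O)CSc1nc(N)c(C#N)c(-c2ccc(Cl)cc2)n1`, is the furthest: in this assay compound 3 gives -23%, beyond the scatter below compound 2. All three numbers sit near zero, so none of the compounds displaces much of the labelled ligand at the concentration tested.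

Compound 4, `COc1ccc(-c2nc(SCC(=O)c3sc(-c4ccccc4)nc3C)[nH]c(=O)c2C#N)cc1OC`, differs from compound 2 in one place: hydrogen in place of methoxy on an aromatic carbon. For the measured compounds named here, only one measured step exists, a number 18.4 percentage points lower from compound 1 to compound 3 (beyond the scatter), and it concerns a different replacement on a different aromatic ring of the shared core, so it does not address the present change directly; it shows only that a single change on an aromatic ring has, once, moved the number modestly downward. Going by the values given here, with no direct precedent, the expected step is small, around a number 4.5 percentage points lower from compound 2 to compound 4 (within the scatter), which would be within the scatter. Compound 4 is therefore estimated at -2%, with a range from -20% to 12%.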

Compound 4, a percentage reported as inhibition, at one concentration (the size of the read-out at that concentration, not a potency): 10%
Estimate against measurement, compound 4: 12 percentage points below; low and high end bracket the measured number.
By their numbers in this assay, from the lowest: compound 3; then compounds 1, 2 and 4 (each within the scatter of the next, the first and the last beyond it).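

Going from 4-methoxyphenyl to phenyl in this assay gives a number 7.5 percentage points higher from compound 2 to compound 4 (within the scatter), so on this read-out the two compounds cannot be told apart and the methoxy para to a large group can go without a measurable change. For the compounds shown here, the only earlier step, a number 18.4 percentage points lower from compound 1 to compound 3 (beyond the scatter), concerned a methoxy on a different aromatic ring and a chloro replacing it, so this is the first reading for the ring that carries the methoxy in compound 2, and the first for a plain hydrogen as the replacement. No measurement shown here accounts for the step.

On these data alone, both numbers are small and come from a single concentration, so a position that looks indifferent here may only reflect how little of the labelled ligand either compound displaces, and whether any group on this carbon can lift the number clearly remains open. A fluorine, an amine or a longer chain such as ethoxy at this place would test that, as would the same hydrogen-for-methoxy change made on the core of compound 1.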